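The source may hold more compounds than are shown below. What is called first, only, known or untested is meant among the compounds shown, and "the series" means these compounds.

Working notes on the series, all read in a functional assay on NCI-H460 cells (Homo sapiens) for inhibition, read by sulforhodamine B assay, with a stated time of 48 h; on this read-out higher numbers stand for weaker inhibition of growth and lower numbers for stronger inhibition of growth. Compound 1 (`CCOC(=O)c1nn(-c2ccc(Cl)cc2)c(-c2ccc(Br)cc2)c1CNC(C)(C)C`) gives > 511000 nM; > 476000 nM (2 entries) as limits of the assay and not as numbers. Compound 2 (`CC(C)(C)NCc1c(C(=O)O)nn(-c2ccccc2)c1-c1ccc([N+](=O)[O-])cc1`) gives > 634000 nM as a limit of the assay. Compound 3 (`CC(C)(C)NCc1c(C(=O)O)nn(-c2ccc(Cl)cc2)c1-c1ccc(Br)cc1`) gives > 542000 nM as a limit of the assay too. Among the measured compounds shown here, compound 3 therefore stands without a number of its own, and no other compound supplies one, so no order among the three can be read.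

The next compound is compound 4 (`CC(C)(C)NCc1c(C(=O)O)nn(-c2ccc(Cl)cc2)c1-c1ccc([N+](=O)[O-])cc1`), where the 4-bromophenyl becomes 4-nitrophenyl: nitro in place of bromo on an aromatic carbon, para to a large group (nitro in place of bromo on an aromatic carbon). For the measured compounds named here, no measured step isolates this change. Compound 2 also carries the 4-nitrophenyl group, and its > 634000 nM is again only a limit.

No change beyond the usual scatter is expected in either direction, and the most likely report is another limit. The expected step, a step that the limit leaves unreadable from compound 3 to compound 4, is an estimate that stays within that scatter. In this assay the estimate for compound 4 is 580000 nM, with an expected range of 300000 nM to 900000 nM as the working figures.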

Compound 4, concentration for 50% growth inhibition: 141000 nM
The estimate for compound 4 lay 4.1-fold (0.61 log units) above the measured number, outside the stated range (below it).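

In this assay the change from 4-bromophenyl to 4-nitrophenyl, on an aromatic carbon para to a large group, gives an at least 3.8-fold lower number from compound 3 to compound 4 (0.58 log units; beyond the scatter), which shows that this position can move the read-out beyond the scatter towards stronger inhibition of growth. Chloro in place of hydrogen on an aromatic carbon gives an at least 4.4-fold lower number from compound 2 to compound 4 (0.65 log units; beyond the scatter), so with the 4-nitrophenyl in place, the chloro site also matters. Both steps start from limits of the assay, so each gives only a minimum size; the steps among compound 1, compound 2 and compound 3 cannot be read, and of the compounds shown only compound 4, which carries 4-nitrophenyl and chloro together, gives a number rather than a limit.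

No measured property in the series bears on why the number is lower, so the result stands without a cause. From the compounds shown here alone, it remains open whether the step is specific to nitro, which a nitrile or an amine on the same aromatic carbon could test, and whether the carboxylic acid of compound 4 matters, which its ethyl ester could test.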